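Replacing 2-hydroxyethyl with methylsulfanyl in compound 1

The compounds below may be only part of what the source reports. "The series", "measured", "known", "first", "only" and "open" are said of these compounds alone.

Compound 1 `Cc1cc(Nc2ccc(C(F)(F)F)cc2)n2nc(CCO)nc2n1`: 67%
Compound 2 `Cc1cc(Nc2cccc(Cl)c2)n2nc(C(C)(F)F)nc2n1`: 88.2%

In an ADME assay on a cell-free system (plasma, Homo sapiens) for protein binding, compound 1 gives 67%, while compound 2 gives 88.2%. Compound 1 therefore has the larger free portion of the two, and the gap lies beyond the usual scatter.

The next compound to be measured is compound 3 `CSc1nc2nc(C)cc(Nc3ccc(C(F)(F)F)cc3)n2n1`. It keeps the rest of compound 1 but carries methylsulfanyl in place of 2-hydroxyethyl on an aromatic carbon. Among the compounds with values here, no measured pair yet isolates a change at this carbon, so any forecast rests on thin evidence. Within the data shown here, the only guide is compound 2, which also lacks the 2-hydroxyethyl group and gives 88.2%, although it differs from compound 1 elsewhere too. On that basis, the estimated step a 3.7-fold lower unbound fraction from compound 1 to compound 3 (0.56 log units; beyond the scatter) is expected to go towards more binding and a smaller free portion, beyond the scatter. For compound 3 the expected value in this assay is 91%, with an estimated range of 80% to 97.5%.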

Compound 3, plasma protein binding: 91.8%
Estimate against measurement, compound 3: 1.1-fold (0.04 log units) (unbound fraction) above, within the range that was stated.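

Placing methylsulfanyl in place of 2-hydroxyethyl on this aromatic carbon, with the rest of compound 1 unchanged, gives in this assay a 4.0-fold lower unbound fraction from compound 1 to compound 3 (0.60 log units; beyond the scatter) and so moves the compound clearly towards more binding. This is the first pair shown that differs only at this carbon, which ties the shift to this one exchange and shows that the group held here, on the five-membered ring between two ring nitrogen atoms, matters for how much of the compound stays free in this assay. The exchange also takes the count of hydrogen-bond donors in this group from 1 to 0 and replaces oxygen with sulfur, but nothing measured here shows which of these differences, if either, accounts for the step.

The compounds shown leave open where an amine, a methoxy group or a longer alkyl chain on this carbon would fall in this assay, so a single pair cannot yet show a trend across groups at this position. On these data alone, it also remains open whether the same exchange would give a step of similar size with something other than the trifluoromethyl-bearing ring on the rest of the molecule.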